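A Thiophene Swap on a Shared Imidazopyrazine Core

The compounds below may be only part of what the source reports. "The series", "measured", "known", "first", "only" and "open" are said of these compounds alone.

Measured so far:
compound 1, `c1ccc2c(-c3cn4ccnc4c(-c4ccc5ncn(C6CCCCC6)c5c4)n3)cccc2c1`, 17.9%
compound 2, `Fc1ccc(-c2cn3ccnc3c(-c3ccc4ncn(C5CCCCC5)c4c3)n2)cc1`, 18%
compound 3, `c1cn2cc(-c3ccsc3)nc(-c3ccc4ncn(C5CCCCC5)c4c3)c2n1`, 13.4%

The three compounds share one core and differ only in the aromatic group attached to it. In a functional assay on HCT-116 cells (Homo sapiens) for inhibition, read by sulforhodamine B assay, with a stated time of 48 h, tested at 10 uM (on this read-out higher numbers stand for more inhibition at the one concentration tested (going by the name of the read-out) and lower numbers for less inhibition), compound 2 gives 18%, the highest of the three numbers, but the steps of a number 0.1 percentage points higher from compound 1 to compound 2 (within the scatter) and a number 4.6 percentage points lower from compound 2 to compound 3 (within the scatter) are both within the scatter, so the three compounds cannot be separated from one another on these numbers.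

Compound 4, `c1csc(-c2cn3ccnc3c(-c3ccc4ncn(C5CCCCC5)c4c3)n2)c1`, has not yet been measured. It differs from compound 2 in one place: thiophen-2-yl in place of 4-fluorophenyl on an aromatic carbon.

Going by the values given here, the steps that bear on this change are a number 4.6 percentage points lower from compound 2 to compound 3 (within the scatter) and a number 4.5 percentage points lower from compound 1 to compound 3 (within the scatter), each of which brings a five-membered sulfur ring in place of a larger carbon ring and each of which stayed within the scatter. Among the compounds with values here, no measured pair compares thiophen-2-yl with thiophen-3-yl directly, so the data cannot say whether the point of attachment matters. Given that every replacement of the aromatic arm so far left the number where it was, a step of a number 3 percentage points lower from compound 2 to compound 4 (within the scatter) is expected, meaning no change beyond the scatter. Compound 4 is therefore estimated to give 15%, with a range from 5% to 27%.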

Compound 4, a percentage reported as inhibition, at one concentration (the size of the read-out at that concentration, not a potency): 21.1%
Compound 4: the middle estimate sits 6.1 percentage points below what was measured; low and high end bracket the measured number.
By their numbers in this assay, from the lowest: compounds 3, 1, 2 and 4 (each within the scatter of the next).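

In this assay, going by these compounds alone, the step of a number 7.7 percentage points higher from compound 3 to compound 4 (within the scatter) is the first direct comparison of the two thiophene attachments at this position, and it shows no readable effect of moving the ring's point of attachment. The steps of a number 3.1 percentage points higher from compound 2 to compound 4 (within the scatter) and a number 3.2 percentage points higher from compound 1 to compound 4 (within the scatter) add to this picture: thiophen-2-yl, a five-membered ring with one sulfur atom, cannot be told apart from either 4-fluorophenyl or naphthalen-1-yl, so all four aromatic groups on this carbon now fall within the scatter of one another. No supporting evidence is available that could account for these numbers.

Every group shown here is an aromatic ring, so it remains open whether an amine, a carboxylic acid or a longer alkyl chain on this same carbon would move the number beyond the scatter. The rest of the shared core also stays the same throughout, so these compounds cannot show whether changes elsewhere in the molecule would have a larger effect on the inhibition seen at this one concentration.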